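A Stereocentre Inverted in a Hydroxamate Series

The source may hold more compounds than are shown below. What is called first, only, known or untested is meant among the compounds shown, and "the series" means these compounds.

Compound 1, `O=C(NO)c1cccc(-c2cn([C@H]3C[C@@H](CO)N(CCCc4ccccc4)C3)nn2)c1`, in an assay on Sf9 cells for inhibition of histone deacetylase 11 (Homo sapiens), read by fluorescence, tested at 0.5 uM (a higher number here means more inhibition at the concentration tested (going by the name of the read-out), a lower number less inhibition), gives < 10%, a limit of the assay rather than a number.
Compound 2, `O=C(NO)c1cccc(-c2cn([C@H]3C[C@@H](C(=O)O)N(Cc4ccccc4)C3)nn2)c1`, in this assay gives 14%.
Compound 3, `O=C(NO)c1cccc(-c2cn([C@H]3C[C@H](CO)N(Cc4ccccc4)C3)nn2)c1`, in this assay gives < 10%, again a limit of the assay and not a number.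

Compound 3 therefore stands at the floor of what this assay reports; as the limit of < 10% in this assay, at which 2 of the 3 values shown sit, shows, it shares that position with compound 1, and none of the three compounds shown reaches a value that stands apart from the others beyond the usual scatter. For the measured compounds named here, no pair of the measured compounds differs in a single place, so no measured step is available to lean on.

Compound 4, `O=C(NO)c1cccc(-c2cn([C@H]3C[C@@H](CO)N(Cc4ccccc4)C3)nn2)c1`, is the partner of compound 3 in which (the two compounds have the same atoms and bonds and differ only in configuration as drawn: 1 of 2 stereo elements differ; a stereocentre at a saturated ring carbon is drawn R in compound 3 and S in compound 4). With every measured compound of this series sitting at or near the limit, and the change confined to configuration at one saturated ring carbon, no move beyond the scatter is expected; the step that the limit leaves unreadable from compound 3 to compound 4 is estimated to be essentially flat. Compound 4 is accordingly expected to give about 8% in this assay, most likely reported as a limit, with a plausible range from 0% to 20%.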

Compound 4, a percentage reported as inhibition, at one concentration (the size of the read-out at that concentration, not a potency): < 10%
Compound 4: no number, only a limit (the forecaster's own chance of this, stated with the estimate: 60%); the middle value does not contradict the limit.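

In this assay compound 4 gives < 10%, which is a limit of the assay, so compound 3 now has a partner of the opposite drawn configuration at this saturated ring carbon and neither form lifts clear of the floor. The steps from compound 3 and from compound 1 cannot be read, since both ends of each are limits, so the inversion can be given no size and no direction: the limit of < 10% in this assay, at which 3 of the 4 values shown sit.

For the compounds shown here, the one step that can be read is hydroxymethyl in place of carboxy on a saturated ring carbon, which gives a number at least 4 percentage points lower from compound 2 to compound 4 (that floor lies within the scatter), so the measured compounds do not separate these two groups at this position.

What stays open is whether the configuration at this carbon matters at all, since the limit hides any difference that may exist within this pair, whose only contrast is this one: the fact that compounds 3 and 4 differ only in the configuration as drawn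

An aminomethyl group or a methyl ester in place of the hydroxymethyl, carried in both configurations, would be needed to show whether this position can move the inhibition off the limit.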